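Chloro for bromo on the thioether ring

A few compounds are considered here, and "the series" means these few. Any claim that something is new, unique, unknown or untested is made for them only; others in the source may bear on it.

Of the compounds shown here, three have so far been tested for how strongly they curb prostate cancer cells in a functional assay on LNCaP cells (Homo sapiens) for cytotoxicity, read by MTT assay; a higher number here means a weaker inhibitor, a lower number a stronger inhibitor.
Compound 1 `CC(O)(CSc1ccc(Cl)cc1)c1nc(-c2ccc(F)c(Cl)c2)no1` gives 26400 nM.
Compound 2 `CC(O)(CSc1ccc(Br)cc1)c1nc(-c2ccc([N+](=O)[O-])c(C(F)(F)F)c2)no1` gives 40000 nM.
Compound 3 `CC(O)(CSc1ccc(F)cc1)c1nc(-c2ccc(F)c(Cl)c2)no1` gives only a limit of the assay, > 100000 nM.

Of the two compounds with a real number, compound 2 has the higher one, and compound 1 stands nearest to it; that gap lies within the scatter of repeated measurements, so the two cannot be ranked. The third value is a limit, not a number.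

Compound 4 `CC(O)(CSc1ccc(Cl)cc1)c1nc(-c2ccc([N+](=O)[O-])c(C(F)(F)F)c2)no1` has not yet been measured. It differs from compound 2 in a single place: chloro in place of bromo on an aromatic carbon. Within the data shown here, no measured pair shows exactly this swap. The nearest comparison on the same ring is an at least 3.7-fold higher number from compound 1 to compound 3 (0.57 log units; beyond the scatter), where the smaller halogen made the inhibitor at least modestly weaker, with the value ending at the limit of > 100000 nM in this assay, at which 1 of the 3 values shown sits. Bromo to chloro is a shorter move down the same series of halogens, so a smaller shift in the same direction is plausible, but it may equally vanish into the scatter.

The step of a 1.3-fold higher number from compound 2 to compound 4 (0.10 log units; within the scatter) is therefore expected to be small, leaning toward a weaker inhibitor. Compound 4 is estimated at 50000 nM, with a likely range from 22000 nM to 110000 nM.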

Compound 4, half-maximal inhibitory concentration: > 100000 nM
Compound 4: no number, only a limit; the forecaster's own chance of this, stated with the estimate: 20%; at least 2.0-fold (0.30 log units) between middle value and limit.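

This position on the thioether ring now responds to a second swap, bromo to chloro, and does so with a different group on the other aryl ring: in this assay there is an at least 2.5-fold higher number from compound 2 to compound 4 (0.39 log units; beyond the scatter). Together with an at least 3.7-fold higher number from compound 1 to compound 3 (0.57 log units; beyond the scatter), this gives two pairs in which moving to the next lighter halogen at this position yields a weaker inhibitor, and no compound shown goes against that pattern, though two pairs are a small basis. The result for compound 4 is a limit, not a number, as is that for compound 3, so each step gives only a lower bound on the true change, and the two steps cannot be compared in size: the limit of > 100000 nM in this assay, at which 2 of the 4 values shown sit.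

The compounds shown leave open how bromo would behave alongside the fluoro and chloro substituted ring of compound 1, which would test whether the halogen trend holds across a complete series on one background. They also leave open what a group other than a halogen, such as a methoxy group, a methyl group or an amine, would do at this position.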